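Amine-chain variant on the calpain-1 series

The source may hold more compounds than are shown below. What is called first, only, known or untested is meant among the compounds shown, and "the series" means these compounds.

Compound 1 `COCCN/C(=C1/N=CN(CCOC)C1=O)c1cc2ccccc2[nH]1` is the reference point of the set. Within the data shown here, in an assay on isolated protein for inhibition of Calpain-1 catalytic subunit (Homo sapiens), read by fluorescence, with a stated time of 60 min (on this read-out higher numbers stand for weaker inhibition and lower numbers for stronger inhibition), compound 1 gives 460 nM, the only plain number among the values shown. Compound 2 `COCCN/C(=C1/N=C(c2ccccc2)N(CCOC)C1=O)c1cc2ccccc2[nH]1` carries a phenyl on the carbon with a double bond to nitrogen where compound 1 carries hydrogen. In this assay compound 2 returns only > 1000 nM, which is a limit of the assay and not a number (the limit of > 1000 nM in this assay, at which 1 of the 2 values shown sits). The recorded step is an at least 2.1-fold higher number from compound 1 to compound 2 (0.33 log units; beyond the scatter).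

Compound 3 `COCCN1C=N/C(=C(/NCCN(C)C)c2cc3ccccc3[nH]2)C1=O` is not yet measured. It differs from compound 1 by dimethylamino in place of methoxy on a saturated chain carbon, two bonds along the chain from an amine nitrogen, a change on the chain attached to the amine nitrogen, with the shared core untouched. Among the measured compounds shown here, no measured step touches this chain: the single step recorded, an at least 2.1-fold higher number from compound 1 to compound 2 (0.33 log units; beyond the scatter), concerns the carbon with a double bond to nitrogen and so offers no direct guide to the size or direction of a change at the chain end. With nothing pushing the expectation either way, compound 3 is expected to land close to compound 1, with a step of a 1.1-fold higher number from compound 1 to compound 3 (0.04 log units; within the scatter) that is not expected to exceed the scatter. The estimate for compound 3 is therefore 500 nM, within the range 150 nM to 1500 nM.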

Compound 3, half-maximal inhibitory concentration: > 1000 nM
Compound 3: a limit, no number; the forecaster's own chance of this, stated with the estimate: 20%; middle value at least 2.0-fold (0.30 log units) away from the limit.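

The chain on the amine nitrogen is not a neutral place in this series: dimethylamino in place of methoxy, on a saturated chain carbon two bonds along the chain from an amine nitrogen, gives an at least 2.1-fold higher number from compound 1 to compound 3 (0.33 log units; beyond the scatter) in this assay and so weakens inhibition beyond the scatter. For compound 3 the entry of > 1000 nM is a limit of the assay and not a number. The series now has two places where a single change moves the read-out the same way, so the hydrogen on the carbon with a double bond to nitrogen is not the only feature of compound 1 that cannot be changed freely, but the true size of the step stays unread and the two changes cannot be ranked: the limit of > 1000 nM in this assay, at which 2 of the 3 values shown sit.

As far as these compounds go, whether the methoxy oxygen itself matters, or whether any other chain end would also weaken inhibition, stays open. A hydroxyl, a primary amine, a carboxylic acid or a longer chain in the same place would separate these cases, and a value inside the range of the assay would give the step a size.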